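Same Piperazinylmethyl Change Tried on a Longer Linker

The compounds below may be only part of what the source reports. "The series", "measured", "known", "first", "only" and "open" are said of these compounds alone.

The series starts from compound 1 `O=C(NCCSc1ccc2c(/C=C/c3ccccn3)n[nH]c2c1)c1cccc(C(F)(F)F)c1`, which in an ADME assay on BaF3 cells (Mus musculus) for antiproliferative activity, read by CCK-8 assay, with a stated time of 72 h (on this read-out higher numbers stand for weaker inhibition of growth and lower numbers for stronger inhibition of growth), gives 1500 nM. Compound 2 `CN1CCN(Cc2ccc(C(=O)NCCSc3ccc4c(/C=C/c5ccccn5)n[nH]c4c3)cc2C(F)(F)F)CC1` differs from it by one change, ((4-methylpiperazin-1-yl)methyl in place of hydrogen on an aromatic carbon), and in this assay compound 2 gives 4800 nM. That single change moved the read-out a 3.2-fold higher number from compound 1 to compound 2 (0.51 log units; beyond the scatter), a weakening that lies beyond the scatter of the measurement.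

Compound 3 `O=C(NCCCSc1ccc2c(/C=C/c3ccccn3)n[nH]c2c1)c1cccc(C(F)(F)F)c1` carries a different core from compound 1; how the two cores differ is not broken down here. In this assay compound 3 gives 980 nM, a number within the scatter of compound 1, so no order between the two can be read from these values, while compound 2 lies clearly above both.

Compound 4 `CN1CCN(Cc2ccc(C(=O)NCCCSc3ccc4c(/C=C/c5ccccn5)n[nH]c4c3)cc2C(F)(F)F)CC1` has not yet been measured. It differs from compound 3 by (4-methylpiperazin-1-yl)methyl in place of hydrogen on an aromatic carbon, and since the surroundings of the new group are described in the same words as for the change from compound 1 to compound 2, it is the same change made on the core of compound 3. For the measured compounds named here, the one earlier example of this change is the step from compound 1 to compound 2, and that is the only evidence available for it.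

Resting on that single step, compound 4 is expected to fall a 3.2-fold higher number from compound 3 to compound 4 (0.50 log units; beyond the scatter), a weakening of similar size to the one seen between compound 1 and compound 2, because of a 3.2-fold higher number from compound 1 to compound 2 (0.51 log units; beyond the scatter). In this assay compound 4 is therefore estimated at 3100 nM, with a plausible range from 1500 nM to 6500 nM.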

Compound 4, concentration for 50% growth inhibition: 4400 nM
The estimate for compound 4 lay 1.4-fold (0.15 log units) below the measured number, within the range that was stated.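

Placing (4-methylpiperazin-1-yl)methyl on the aromatic carbon ortho to the trifluoromethyl group again weakened growth inhibition in this assay, with a 4.5-fold higher number from compound 3 to compound 4 (0.65 log units; beyond the scatter). Set beside the earlier example, the two steps cannot be told apart in size: the same change on two cores in this assay, a 3.2-fold higher number (0.51 log units; beyond the scatter) from compound 1 to compound 2 and a 4.5-fold higher number (0.65 log units; beyond the scatter) from compound 3 to compound 4, 1.4-fold (0.15 log units) apart, within the scatter of two such steps. On these two cores, then, the change carried over in both direction and size, but two matched pairs are a narrow base, and they show neither that the same would hold on any other core nor why the number rises.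

The compounds shown leave open whether a morpholin-4-ylmethyl or a dimethylaminomethyl group at the same place would give a step of similar size, and whether the step would persist if a different group took the place of the trifluoromethyl group. For the compounds shown here, also open is whether the change would behave in the same way on a core with a longer chain on the sulfur than the one in compound 3 and compound 4, since only two chain lengths appear in this part of the series.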